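This account rests on a few compounds, and the source may have more. Where it says the series, first, only, none or still open, it means among the compounds named here.

In a functional assay on DU-145 cells (Homo sapiens) for antiproliferative activity, read by sulforhodamine B assay, with a stated time of 3 days (on this read-out lower numbers stand for stronger inhibition of growth and higher numbers for weaker inhibition of growth), compound 1 `O=C(Nc1ccccn1)c1cccc(Nc2ncc(F)c(Nc3ccc(F)cc3)n2)c1` gives 15100 nM. Compound 2 `O=C(Nc1cccc(Nc2ncc(F)c(Nc3ccc(F)cc3)n2)c1)c1ccccc1` is reported only as a limit, > 10000 nM. Among the measured compounds shown here, the one measured step is a step that the limit leaves unreadable from compound 1 to compound 2, and it offers no size to carry forward. The evidence on this stretch of the series is the limit of > 10000 nM in this assay, at which 1 of the 2 values shown sits. Compound 3 `Cn1ccnc1NC(=O)c1cccc(Nc2ncc(F)c(Nc3ccc(F)cc3)n2)c1` differs from compound 2 by a single change on an aromatic carbon: (1-methyl-1H-imidazol-2-yl)carbamoyl in place of benzamido on an aromatic carbon. In words, (1-methyl-1H-imidazol-2-yl)carbamoyl replaces benzamido. For the measured compounds named here, with no readable step available, the only numerical anchor is compound 1, which carries (pyridin-2-yl)carbamoyl and gives 15100 nM. The step expected in this assay is a step that the limit leaves unreadable from compound 2 to compound 3, with no change beyond the scatter anticipated. For compound 3 the estimate is 12000 nM, with an expected range of 5000 nM to 30000 nM.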

Compound 3, concentration for 50% growth inhibition: 15100 nM
For compound 3 the middle estimate is 1.3-fold (0.10 log units) below the measured one; low and high end bracket the measured number.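

In this assay, 1-methyl-1H-imidazol-2-yl in place of pyridin-2-yl on the amide-type nitrogen is no change at the digits printed from compound 1 to compound 3 (within the scatter). Among the compounds shown here, this is the first readable comparison at this position: the two groups cannot be told apart on growth inhibition, which compound 1 and compound 2 alone could not show. Compound 2 stands only as a limit, so the steps that touch it cannot be read and the benzamido comparison stays open: the limit of > 10000 nM in this assay, at which 1 of the 3 values shown sits.

The compounds shown leave open whether any group on this amide nitrogen moves the value beyond the scatter, for instance a simple amine-bearing chain or a carboxylic acid in place of the 1-methyl-1H-imidazol-2-yl. They also leave open whether the lack of change seen here extends beyond these two groups.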